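The compounds below may be only part of what the source reports. "The series", "measured", "known", "first", "only" and "open" are said of these compounds alone.

Measured compounds in a functional assay on HCT-116 cells (Homo sapiens) for cytotoxicity, read by sulforhodamine B assay; on this read-out higher numbers stand for weaker inhibition and lower numbers for stronger inhibition:

Compound 1, `[N-]=[N+]=N[C@@H]1C(n2ccc(=O)[nH]c2=O)[Se][C@H](CO)[C@H]1O`: in this assay compound 1 gives > 100000 nM, a limit of the assay rather than a number.
Compound 2, `[N-]=[N+]=N[C@@H]1C(n2cc(F)c(=O)[nH]c2=O)[Se][C@H](CO)[C@H]1O`: in this assay compound 2 gives > 100000 nM, again a limit.
Compound 3, `[N-]=[N+]=N[C@@H]1C(n2cc(Cl)c(=O)[nH]c2=O)[Se][C@H](CO)[C@H]1O`: in this assay compound 3 gives > 100000 nM, also a limit.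

All three compounds share one core and differ only in the group on the same aromatic carbon. Among the compounds with values here, compound 3 stands where the other two stand: at the limit of > 100000 nM in this assay, at which 3 of the 3 values shown sit, so no compound can be ranked against another. The steps a step that the two limits leave unreadable from compound 1 to compound 2, a step that the two limits leave unreadable from compound 1 to compound 3 and a step that the two limits leave unreadable from compound 2 to compound 3 bear on the change ahead, but each joins two limits and its size cannot be read.

Compound 4, `[N-]=[N+]=N[C@@H]1C(n2cc(I)c(=O)[nH]c2=O)[Se][C@H](CO)[C@H]1O`, is not yet measured. It differs from compound 3 by iodo in place of chloro on an aromatic carbon. With nothing but limits to go on, no step beyond the scatter is expected, and compound 4 is expected to sit at the limit as well, a step that the limit leaves unreadable from compound 3 to compound 4. The estimate for compound 4 is 200000 nM, with a range from 50000 nM to 1000000 nM.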

Compound 4, half-maximal inhibitory concentration: > 100000 nM
Compound 4: no number, only a limit; the forecaster's own chance of this, stated with the estimate: 85%; the middle value does not contradict the limit.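

Compound 4, like compound 1, compound 2 and compound 3, gives only a limit in this assay, so none of its steps to them can be read: the limit of > 100000 nM in this assay, at which 4 of the 4 values shown sit. The compounds shown leave open how far each one lies past that limit, and whether they differ at all.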